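Chloro for fluoro on the 2-substituted phenyl ring

The source may report more compounds than this note shows. Statements on the series, on what has been measured and on what is new or still open speak of the compounds shown alone.

Measured so far:
compound 1, `CN1C(=O)C(c2ccc(F)cc2)N(C)c2nc(Nc3ccc(S(N)(=O)=O)cc3)ncc21`: in an assay on Sf9 cells for inhibition of serine/threonine-protein kinase 4 (Homo sapiens), read by luminescence and ADP-Glo, with a stated time of 1 h, in the presence of a further agent that is not named here (a higher number here means a weaker inhibitor, a lower number a stronger inhibitor), compound 1 gives 1770 nM
compound 2, `CN1C(=O)C(c2ccccc2F)N(C)c2nc(Nc3ccc(S(N)(=O)=O)cc3)ncc21`: in this assay compound 2 gives 75 nM

Compound 2 stands lowest of the two numbers in this assay. Within the data shown here, its only neighbour is compound 1, and the single measured step, a 24-fold lower number from compound 1 to compound 2 (1.37 log units; beyond the scatter), is large and beyond the scatter.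

Compound 3, `CN1C(=O)C(c2ccccc2Cl)N(C)c2nc(Nc3ccc(S(N)(=O)=O)cc3)ncc21`, has not been measured. It differs from compound 2 by chloro in place of fluoro on an aromatic carbon. Among the measured compounds shown here, no measured step bears directly on this exchange: the one step on record, a 24-fold lower number from compound 1 to compound 2 (1.37 log units; beyond the scatter), moves a fluoro from one aromatic carbon to another and says nothing about fluoro against chloro. In this assay compound 3 is therefore expected to remain close to compound 2. The expected step is a 1.1-fold higher number from compound 2 to compound 3 (0.03 log units; within the scatter), not beyond the scatter. The estimate for compound 3 is 80 nM, with a range from 30 nM to 220 nM.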

Compound 3, half-maximal inhibitory concentration: 129 nM
Compound 3: the middle estimate sits 1.6-fold (0.21 log units) below what was measured, and the stated range covers the measured number.
By their numbers in this assay, from the lowest: compounds 2 and 3 (each within the scatter of the next); then compound 1.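

In this assay, chloro in place of fluoro on the aromatic carbon ortho to a large group gives a 1.7-fold higher number from compound 2 to compound 3 (0.24 log units; within the scatter) and so does not separate the two halogens at this place. The 2-chlorophenyl group in place of 4-fluorophenyl gives a 14-fold lower number from compound 1 to compound 3 (1.14 log units; beyond the scatter) as a second large step, so the gap to compound 1 seen with compound 2 also holds for compound 3, with a different halogen on the phenyl ring. The data shown offer no measured basis for explaining either step.

The compounds shown leave open whether a halogen is needed at this place at all, since a methyl group, a methoxy group or plain hydrogen there would test that directly. Also open, as far as these compounds go, is how 4-chlorophenyl compares with 4-fluorophenyl on the same saturated ring carbon.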